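A Fused Bicycle Replaces the Aryl Ether on the Core

A few compounds are considered here, and "the series" means these few. Any claim that something is new, unique, unknown or untested is made for them only; others in the source may bear on it.

Of the compounds shown here, three built on one shared core have been measured in an ADME assay on HepG2 cells (Homo sapiens) for cytotoxicity, read by luminescence, CellTiter-Glo and ATP content, with a stated time of 72 h; on this read-out lower numbers stand for an effect already at smaller amounts and higher numbers for an effect only at larger amounts of compound. Compound 1 `COc1ccc(-c2ccc3c(NCCCNCc4cccc(OC)c4O)ccnc3c2)cc1` gives 1600 nM, compound 2 `COc1cccc(CNCCCNc2ccnc3cc(-c4ccc(C(C)(C)C)cc4)ccc23)c1O` gives 690 nM, and compound 3 `COc1cccc(CNCCCNc2ccnc3cc(Oc4ccc(C(C)(C)C)cc4)ccc23)c1O` gives 1500 nM. Among these three numbers compound 3 stands second highest; its nearest neighbour is compound 1, whose value lies within the scatter of its own, while the step of a 2.2-fold higher number from compound 2 to compound 3 (0.34 log units; beyond the scatter) is modest but beyond the scatter.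

Compound 4 `COc1cccc(CNCCCNc2ccnc3cc(-c4cccc5ccccc45)ccc23)c1O` differs from compound 3 in a single place: naphthalen-1-yl in place of 4-(tert-butyl)phenoxy on an aromatic carbon. Among the measured compounds shown here, two measured steps bear on this change. The step of a 2.2-fold higher number from compound 2 to compound 3 (0.34 log units; beyond the scatter) shows what happened when a directly attached aryl gave way to an aryl ether, and the step of a 2.3-fold lower number from compound 1 to compound 2 (0.37 log units; beyond the scatter) shows what a larger hydrocarbon substituent did in place of a smaller oxygen-bearing one. Compound 4 brings back a directly attached aryl and adds a second aromatic ring, so a modest downward step in this assay is expected, towards compound 2, whose value 690 nM serves as the anchor. The estimate for compound 4 is 800 nM with a range from 350 nM to 1800 nM, which corresponds to an expected step of a 1.9-fold lower number from compound 3 to compound 4 (0.27 log units; within the scatter).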

Compound 4, half-maximal effective concentration: 2520 nM
The estimate for compound 4 lay 3.2-fold (0.50 log units) below the measured number; measured number outside the range, above it.
By their numbers in this assay, from the lowest: compound 2; then compounds 3, 1 and 4 (each within the scatter of the next).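

In this assay, among the compounds shown here, a directly attached aryl at this position does not by itself give the low number of compound 2: a 3.7-fold higher number from compound 2 to compound 4 (0.56 log units; beyond the scatter), a modest step beyond the scatter, and the only change is naphthalen-1-yl in place of 4-(tert-butyl)phenyl. Compound 4 instead falls in with the other two compounds, with a 1.7-fold higher number from compound 3 to compound 4 (0.23 log units; within the scatter) and a 1.6-fold higher number from compound 1 to compound 4 (0.20 log units; within the scatter), both within the scatter, so neither the swap for the 4-(tert-butyl)phenoxy group nor that for the 4-methoxyphenyl group can be told apart here. Among these four compounds the lower number therefore goes with the 4-(tert-butyl)phenyl group of compound 2 and not with direct attachment of an aryl as such, with compound 1 and compound 4 standing against the latter reading.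

Nothing measured here accounts for the gap between the naphthalen-1-yl and 4-(tert-butyl)phenyl groups. From the compounds shown here alone, how an unsubstituted phenyl, a naphthalen-2-yl or a morpholine on this aromatic carbon would read remains open, and so does whether the tert-butyl group itself carries the difference.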